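Methoxy for chloro on a poorly soluble urea

This account rests on a few compounds, and the source may have more. Where it says the series, first, only, none or still open, it means among the compounds named here.

Values in a physicochemical assay for solubility, at pH 7.4 (on this read-out lower numbers stand for lower solubility and higher numbers for higher solubility), for the measured compounds:
compound 1 `COc1ccc(NC(=O)Nc2cc(C)nc3ccccc23)cc1OC` gives 4100 nM
compound 2 `Cc1cc(NC(=O)Nc2ccc(C(F)(F)F)cc2)c2ccccc2n1` gives 100 nM
compound 3 `Cc1cc(NC(=O)Nc2ccc(Cl)cc2)c2ccccc2n1` gives 1400 nM

Compound 3 stands second highest of the three, its 1400 nM lying under the value of compound 1 and over the value of compound 2. Compound 4 `COc1ccc(NC(=O)Nc2cc(C)nc3ccccc23)cc1` has not yet been measured and differs from compound 3 thus: methoxy in place of chloro on an aromatic carbon with methoxy in place of chloro on an aromatic carbon, para to a large group.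

Going by the values given here, one measured step bears on this change: a 14-fold higher number from compound 2 to compound 3 (1.15 log units; beyond the scatter) and this large step has chloro in place of trifluoromethyl on an aromatic carbon. It shows that exchanging one group can move the number far, but it says nothing about methoxy itself. Among the compounds with values here, compound 1, the one measured compound carrying methoxy, gives 4100 nM as its value, which stands over that of compound 3, though no measured step links it to compound 3 or compound 4. Within the data shown here, a small upward move is therefore expected, with a 1.8-fold higher number from compound 3 to compound 4 (0.25 log units; within the scatter) as the estimated step, and no step clearly beyond the scatter. For compound 4 the estimated value is 2500 nM with an expected span from 900 nM to 7000 nM around that middle.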

Compound 4, solubility: 19800 nM
Beside the measured number, compound 4's estimate is 7.9-fold (0.90 log units) below it; measured number above the stated range.
By their numbers in this assay, from the lowest: compound 2; then compound 3; then compound 1; then compound 4.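

At the position para to a large group, methoxy in place of chloro in this assay proved a large change rather than a small one, with a 14-fold higher number from compound 3 to compound 4 (1.15 log units; beyond the scatter) as its step, so the earlier trifluoromethyl to chloro step was not the only large move at this place. Taken together across the three groups on this carbon, the order runs trifluoromethyl, chloro, methoxy from low to high, and the whole span is a 200-fold higher number from compound 2 to compound 4 (2.30 log units; beyond the scatter) in this series of three. The second methoxy of compound 1 does not add to this rise, since hydrogen in its place gives a 4.8-fold higher number from compound 1 to compound 4 (0.68 log units; beyond the scatter) and so compound 4, with the single methoxy, stands highest of the four.

As far as these compounds go, whether that order extends to other groups on this carbon, such as an amine, a hydroxyl or a carboxylic acid, or to a longer chain in place of methoxy, stays open, as does whether methoxy in place of chloro moves the number as far on another core. Nothing among the data shown accounts for the size of these steps or tells what lies behind them.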